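Swapping cyclopropyl for isopropyl on a high-solubility compound

The source may report more compounds than this note shows. Statements on the series, on what has been measured and on what is new or still open speak of the compounds shown alone.

Among the measured compounds shown here, in a physicochemical assay for solubility, read by mass spectrometry, in phosphate buffer, with a stated time of 24 h, at pH 7.4 (on this read-out higher numbers stand for higher solubility and lower numbers for lower solubility), compound 1 (`O=C(Nc1ccc(OC(F)(F)F)c(F)c1)NC1CCN(C(=O)C2CC2)CC1`) gives 19 ug/mL and holds the highest of the three numbers measured so far. Compound 2 (`Cc1occc1C(=O)N1CCC(NC(=O)Nc2ccc(OC(F)(F)F)cc2)CC1`) comes nearest at 8.6 ug/mL yet stays clearly lower, and compound 3 (`O=C(Nc1ccc(C(F)(F)F)c(F)c1)NC1CCN(C(=O)C2CC2)CC1`) lies furthest away at 0.46 ug/mL at the bottom of the set.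

Compound 4 (`CC(C)C(=O)N1CCC(NC(=O)Nc2ccc(OC(F)(F)F)c(F)c2)CC1`) departs from compound 1 in a single place (isopropyl in place of cyclopropyl on a carbonyl carbon) with isopropyl in place of cyclopropyl on a carbonyl carbon. The rest of the molecule stays as it was.

For the measured compounds named here, only one measured step links two compounds through a single change. That step runs a 41-fold lower number from compound 1 to compound 3 (1.62 log units; beyond the scatter) and is large, well beyond the scatter, with trifluoromethyl in place of trifluoromethoxy on an aromatic carbon. It shows how far one change can move this assay in this series, but it concerns a different group. Going by the values given here, no measured step changes the group on the carbonyl alone, so the data offer no direction for this swap.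

The expected step of a 1.2-fold lower number from compound 1 to compound 4 (0.07 log units; within the scatter) is small and stays within the scatter. In this assay compound 4 is estimated at 16 ug/mL with an expected range from 5 ug/mL to 45 ug/mL as a deliberately wide span.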

Compound 4, solubility: 5.3 ug/mL
The estimate for compound 4 lay 3.0-fold (0.48 log units) above the measured number; the measured number falls inside the stated range.
By their numbers in this assay, from the lowest: compound 3; then compounds 4 and 2 (each within the scatter of the next); then compound 1.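

In this assay, among the compounds shown here, the swap gives a 3.6-fold lower number from compound 1 to compound 4 (0.55 log units; beyond the scatter) and so supplies the first measured step at this position, on a carbonyl carbon whose other neighbour is an amide-type nitrogen in a ring. The group here therefore matters to the read-out even though cyclopropyl and isopropyl both hold 3 heavy atoms, with no hydrogen-bond donors or acceptors and no net charge, and differ in that only cyclopropyl is a ring. For the compounds shown here, the step is still much smaller than a 41-fold lower number from compound 1 to compound 3 (1.62 log units; beyond the scatter) in the same series, so this change moves the number less than the trifluoromethyl swap on the aromatic carbon does, and with only one pair behind it no general rule about rings at this position follows. No measurement at hand explains why the number falls with this change.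

The compounds shown leave open whether a cyclobutyl ring, a longer chain such as n-butyl or a carbonyl group carrying an amine would stay close to compound 1 or drop as compound 4 does. They also leave open whether the same swap from cyclopropyl to isopropyl would shift compound 3 to a similar extent.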